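The compounds below may be only part of what the source reports. "The series", "measured", "known", "first", "only" and "open" are said of these compounds alone.

Measured in a functional assay on HepG2 cells (Homo sapiens) for inhibition, read by MTT assay, with a stated time of 72 h; a higher number here means a weaker inhibitor, a lower number a stronger inhibitor:
Compound 1 `O=C(Nc1ccccc1)C1CCN(C/C=C/c2ccccc2)CC1`: 90900 nM
Compound 2 `O=C(Nc1cccc(F)c1)C1CCN(C/C=C/c2ccccc2)CC1`: 51100 nM

In this assay, among the compounds with values here, compound 2 stands within the scatter of compound 1, the only other compound measured. Compound 3 `O=C(Nc1cccc(Br)c1)C1CCN(C/C=C/c2ccccc2)CC1` differs from compound 2 by bromo in place of fluoro on an aromatic carbon. Within the data shown here, the one measured step that bears on this, a 1.8-fold lower number from compound 1 to compound 2 (0.25 log units; within the scatter), placed fluoro in place of hydrogen on the same aromatic carbon and stayed within the scatter. No step beyond the scatter is therefore expected. The estimated step is a 1.2-fold lower number from compound 2 to compound 3 (0.09 log units; within the scatter). For compound 3 the expected value is 42000 nM, with an estimated range of 18000 nM to 95000 nM.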

Compound 3, half-maximal inhibitory concentration: 19200 nM
Compound 3: middle estimate off by 2.2-fold (0.34 log units), on the high side; the measured number falls inside the stated range.
By their numbers in this assay, from the lowest: compound 3; then compounds 2 and 1 (each within the scatter of the next).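

In this assay this position on the aromatic ring, meta to a large group, now shows a real response to substitution: bromo in place of fluoro gives a 2.7-fold lower number from compound 2 to compound 3 (0.43 log units; beyond the scatter) and bromo in place of hydrogen gives a 4.7-fold lower number from compound 1 to compound 3 (0.68 log units; beyond the scatter) while fluoro in place of hydrogen had stayed within the scatter. The identity of the halogen therefore matters here, though the size of the gain remains modest. Nothing available explains this difference between bromo and fluoro. From the compounds shown here alone, whether chloro, methoxy or an amine at this carbon would follow bromo or fluoro remains open, as does the effect of bromo elsewhere on the ring.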